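Hydroxy removal on the aryl ring of compound 3

The source may report more compounds than this note shows. Statements on the series, on what has been measured and on what is new or still open speak of the compounds shown alone.

Of the compounds shown here, three of a shared core have been measured in a functional assay on NCI/ADR-RES cells (Homo sapiens) for inhibition, read by sulforhodamine B assay, with a stated time of 48 h; a higher number here means a weaker inhibitor of growth, a lower number a stronger inhibitor of growth. Compound 1 `CCOC(=O)C1=C(C)NC(=S)NC1c1ccc(O)c(O)c1` gives 24.3 ug/mL in this assay. Compound 2 `CCOC(=O)C1=C(C)NC(=S)NC1c1cc(OC)c(O)c(OC)c1` gives 25 ug/mL in this assay. Compound 3 `CCOC(=O)C1=C(C)NC(=O)NC1c1ccc(O)c(O)c1` carries a carbonyl in the core where compounds 1 and 2 carry a thiocarbonyl. In this assay compound 3 gives 2.1 ug/mL. Compound 3 stands lowest of the three numbers; its gaps to compound 1 and to compound 2 are both beyond the usual scatter, so compound 3 is the strongest inhibitor of growth of the three. Among the measured compounds shown here, no two measured compounds differ in a single place, so no single-change step is available.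

Compound 4 `CCOC(=O)C1=C(C)NC(=O)NC1c1ccc(O)cc1` is to be measured in this assay. It differs from compound 3 in one place: hydrogen in place of hydroxy on an aromatic carbon. The hydroxy that leaves sits ortho to a hydroxy group and meta to a large group. Compounds 1 and 2 differ from compound 3 in more than one place, so the measured set shows nothing about such a removal on its own. The expected step of a 2.4-fold higher number from compound 3 to compound 4 (0.38 log units; beyond the scatter) is toward a higher number, of modest size and with a wide range. Compound 4 is expected to give 5 ug/mL in this assay, between 1.5 ug/mL and 20 ug/mL.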

Compound 4, concentration for 50% growth inhibition: 3.2 ug/mL
The estimate for compound 4 lay 1.6-fold (0.19 log units) above the measured number; the measured number falls inside the stated range.
By their numbers in this assay, from the lowest: compounds 3 and 4 (each within the scatter of the next); then compounds 1 and 2 (each within the scatter of the next).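

Replacing hydroxy with hydrogen on this aromatic carbon, ortho to a hydroxy group and meta to a large group, gives a 1.5-fold higher number from compound 3 to compound 4 (0.18 log units; within the scatter) in this assay. Among the compounds shown here, this is the first single-change reading, and it shows that this hydroxy is not required for the low number seen with compound 3, since the two compounds cannot be told apart within the scatter of this measurement and the remaining hydroxy alone is enough to keep compound 4 level with compound 3. No measurement bearing on the reason for this result is available.

On these data alone, it remains open whether an amine or a carboxylic acid on this same aromatic carbon would also stay within the scatter of compound 3, or would move the number in either direction. Also open, as far as these compounds go, are whether the hydroxy remaining in compound 4 can be replaced by hydrogen with as little effect, and whether the same change would read alike on the thiocarbonyl core of compound 1.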